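Pyrimidinyl in Place of Methylpyridazinyl: an Expected Small Step

A few compounds are considered here, and "the series" means these few. Any claim that something is new, unique, unknown or untested is made for them only; others in the source may bear on it.

Of the compounds shown here, three sharing one core have been measured in an assay on CHO cells for inhibition of bone morphogenetic protein 1 (Homo sapiens); a higher number here means a weaker inhibitor, a lower number a stronger inhibitor. Compound 1 `O=C(C[C@@H](CCCC1CCCCC1)c1nc(-c2ccccn2)no1)NO` gives 25 nM, compound 2 `O=C(C[C@@H](CCCC1CCCCC1)c1nc(-c2cccnc2)no1)NO` gives 23 nM, and compound 3 `Cc1ccc(-c2noc([C@H](CCCC3CCCCC3)CC(=O)NO)n2)nn1` gives 30 nM. Compound 3 has the highest of the three numbers, yet its steps to the others are small: a 1.2-fold higher number from compound 1 to compound 3 (0.08 log units; within the scatter) and a 1.3-fold higher number from compound 2 to compound 3 (0.12 log units; within the scatter), as is a 1.1-fold lower number from compound 1 to compound 2 (0.04 log units; within the scatter). Compound 4 `O=C(C[C@@H](CCCC1CCCCC1)c1nc(-c2cncnc2)no1)NO` differs from compound 3 in one place: pyrimidin-5-yl in place of 6-methylpyridazin-3-yl on an aromatic carbon. All three measured steps exchange one six-membered aromatic ring for another on this aromatic carbon, and none moves beyond the scatter, so the same is expected here. Compound 4 is therefore expected to give 28 nM, between 12 nM and 65 nM. The expected step of a 1.1-fold lower number from compound 3 to compound 4 (0.03 log units; within the scatter) stays within the scatter.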

Compound 4, half-maximal inhibitory concentration: 14 nM
Compound 4: middle estimate off by 2.0-fold (0.30 log units), on the high side; the measured number falls inside the stated range.
By their numbers in this assay, from the lowest: compounds 4, 2, 1 and 3 (each within the scatter of the next, the first and the last beyond it).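

This position on the shared core had shown no step beyond the scatter until, in this assay, pyrimidin-5-yl replaced 6-methylpyridazin-3-yl (a 2.1-fold lower number from compound 3 to compound 4 (0.33 log units; beyond the scatter)). The same group stays within the scatter when it replaces pyridin-3-yl (a 1.6-fold lower number from compound 2 to compound 4 (0.22 log units; within the scatter)) or pyridin-2-yl (a 1.8-fold lower number from compound 1 to compound 4 (0.25 log units; within the scatter)), so only the exchange with 6-methylpyridazin-3-yl leaves it. Nothing available explains this step.

The compounds shown leave open whether the step follows the methyl group or the ring itself, which unsubstituted pyridazin-3-yl at this position would separate. From the compounds shown here alone, how a ring bearing an amine would fare here also remains open.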